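The source may report more compounds than this note shows. Statements on the series, on what has been measured and on what is new or still open speak of the compounds shown alone.

In an ADME assay on the whole organism (Mus musculus, strain BALB/c) for pharmacokinetics, read by LC-MS, with a stated time of 600 min, at a dose of 20 mg/kg by the intravenous route (on this read-out higher numbers stand for higher exposure at the dose given and lower numbers for lower exposure), compound 1 (`CN(CCCNC(=O)Nc1ccc(C(C)(C)C)cc1)C[C@H]1C[C@@H](c2ccc3c(N)ncnn23)[C@H](O)[C@@H]1O`) gives 16300 nM and compound 2 (`CC(C)NC[C@@H]1C[C@H](c2ccc3c(N)ncnn23)[C@@H](O)[C@H]1O`) gives 60300 nM as the higher of the two numbers, a gap beyond the scatter. Compound 3 (`CC(C)NC[C@H]1C[C@@H](c2ccc3c(N)ncnn23)[C@H](O)[C@@H]1O`) has not yet been measured. Compared with compound 2 the change is the two compounds have the same atoms and bonds and differ only in configuration as drawn: 4 of 4 stereo elements differ (all stereocentres are inverted: mirror images); a stereocentre at a saturated ring carbon is drawn S in compound 2 and R in compound 3; a stereocentre at a saturated ring carbon is drawn R in compound 2 and S in compound 3; a stereocentre at a saturated ring carbon is drawn R in compound 2 and S in compound 3; a stereocentre at a saturated ring carbon is drawn S in compound 2 and R in compound 3 and the two have the same atoms and bonds. Among the measured compounds shown here, no measured pair shows what such an inversion does in this assay for these compounds. The expected 1.4-fold lower number from compound 2 to compound 3 (0.16 log units; within the scatter) stays within the scatter, leaning slightly downward if anything. Compound 3 is estimated at 42000 nM (expected range 16000 nM to 100000 nM).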

Compound 3, maximal plasma concentration: 134000 nM
The estimate for compound 3 lay 3.2-fold (0.50 log units) below the measured number; measured number above the stated range.
By their numbers in this assay, from the lowest: compound 1; then compound 2; then compound 3.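

Among these compounds, the first pair differing in one respect shows that stereochemistry alone moves the read-out in this assay: a 2.2-fold higher number from compound 2 to compound 3 (0.35 log units; beyond the scatter). With no atom or bond changed, this step rests on the inversion of all the stereocentres, because nothing else separates the mirror-image pair: the fact that compounds 2 and 3 differ only in the configuration as drawn.

Which of the inverted stereocentres matter, and whether the same inversion would raise the number for compound 1, stays open. So does whether a cyclopropyl amine would respond to inversion in the same way.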